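The compounds below may be only part of what the source reports. "The series", "measured", "known", "first", "only" and "open" are said of these compounds alone.

Three compounds have been measured in a functional assay on CHO-K1 cells for agonist activity at Glucose-dependent insulinotropic receptor (Homo sapiens), read by a luciferase reporter, with a stated time of 5 h; a lower number here means that less compound is needed, a higher number that more compound is needed for the effect:

- compound 1 `CC(C)OC(=O)N1CCC(Oc2cccc3c2CCN3c2ccc(S(C)(=O)=O)cc2)CC1` gives 501 nM;
- compound 2 `CCCOC(=O)N1CCC(Oc2ncnc3c2CCN3c2ccc(S(C)(=O)=O)cc2F)CC1` gives 79.4 nM;
- compound 3 `CCSC(=O)N1CCC(Oc2ncnc3c2CCN3c2ccc(S(C)(=O)=O)cc2F)CC1` gives 31.6 nM.

Compound 2 stands second highest of these three numbers; its nearest neighbour is compound 3, and compound 1 lies furthest away, a higher number still. Going by the values given here, the only measured step that changes a single place runs from compound 2 to compound 3: a 2.5-fold lower number from compound 2 to compound 3 (0.40 log units; beyond the scatter). The compound now in question, compound 4 `CC(C)c1noc(N2CCC(Oc3ncnc4c3CCN4c3ccc(S(C)(=O)=O)cc3F)CC2)n1`, keeps the rest of compound 2 and alters that same place: 3-isopropyl-1,2,4-oxadiazol-5-yl in place of propoxycarbonyl on an amine nitrogen in a ring. Here the whole propoxycarbonyl is exchanged for a five-membered aromatic ring rather than one chain being swapped for another, so the single measured step is only a loose guide. Among the compounds with values here, what it does show is that the one change already made at this position moved the number downward, not upward, and by a modest amount. Compound 4 is therefore expected to show a 1.6-fold lower number from compound 2 to compound 4 (0.20 log units; within the scatter) in this assay, with a range wide enough to include no change beyond the scatter. The estimated value for compound 4 is 50 nM, between 15 nM and 160 nM.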

Compound 4, half-maximal effective concentration: 79.4 nM
The estimate for compound 4 lay 1.6-fold (0.20 log units) below the measured number; measured number inside the range.
By their numbers in this assay, from the lowest: compound 3; then compounds 2 and 4 (each within the scatter of the next); then compound 1.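

In this assay, no change at the digits printed from compound 2 to compound 4 (within the scatter) when 3-isopropyl-1,2,4-oxadiazol-5-yl takes the place of propoxycarbonyl. This position, on an amine nitrogen in a ring, therefore tolerates a five-membered aromatic ring with 3 hetero atoms, and the double bond of the carbonyl outside an aromatic ring is not needed to keep the number of compound 2. The sulfur-containing group still sets the lower mark among these three groups, since a 2.5-fold higher number from compound 3 to compound 4 (0.40 log units; beyond the scatter) when the new ring replaces (ethylsulfanyl)carbonyl, so the ring matches the propoxycarbonyl but not the (ethylsulfanyl)carbonyl. Nothing among the data shown gives a reason for these numbers.

Going by these compounds alone, the single ring compound cannot separate the contribution of the oxadiazole ring from that of its isopropyl group, so a methyl or a tert-butyl group in that spot could show which of the two matters. Going by these compounds, it also stays open whether a six-membered aromatic ring such as a pyrimidine on the same nitrogen would hold the number, or move it towards that of compound 3.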